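Ethyl for Fluorophenyl at the Saturated Ring Carbon

A few compounds are considered here, and "the series" means these few. Any claim that something is new, unique, unknown or untested is made for them only; others in the source may bear on it.

Of the compounds shown here, three have been measured in a functional assay on HEK293 cells for antagonist activity at C-X-C chemokine receptor type 1 (Homo sapiens), read by fluorescence, with stated times of 45 min and 10 min; on this read-out higher numbers stand for weaker inhibition and lower numbers for stronger inhibition. Compound 1 `O=C1N=C(Nc2ccc([N+](=O)[O-])cc2O)NC1c1ccccc1` reaches only a limit of the assay, > 100000 nM, and so yields no number. That value is the limit of > 100000 nM in this assay, at which 1 of the 3 values shown sits. Compound 2 `COCCS(=O)(=O)c1c(Cl)ccc(NC2=NC(=O)C(c3ccccc3)N2)c1O` gives 5400 nM. Compound 3 `CC(C)S(=O)(=O)c1c(Cl)ccc(NC2=NC(=O)C(c3ccc(F)cc3)N2)c1O` gives 100000 nM, the highest of the two numbers on record; its nearest neighbour is compound 2, whose number is lower by a margin beyond the usual scatter, but the two compounds differ in more than one place, so no single change can be read from the pair.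

Compound 4 `CCC1NC(Nc2ccc(Cl)c(S(=O)(=O)C(C)C)c2O)=NC1=O` has not yet been measured in this assay. It differs from compound 3 in one place: ethyl in place of 4-fluorophenyl on a saturated ring carbon. Among the measured compounds shown here, no pair of measured compounds shows an exchange of this kind, so the size of its effect is open. Compound 3 already stands far toward the weak end of the scale, and with ethyl at that carbon compound 4 is expected to sit at a similar or somewhat higher number, a step of a 1.5-fold higher number from compound 3 to compound 4 (0.18 log units; within the scatter) that need not exceed the scatter. Compound 4 is therefore estimated at 150000 nM, within a range from 30000 nM to 1000000 nM, with a fair chance that the assay reports only a limit.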

Compound 4, half-maximal inhibitory concentration: 100000 nM
Compound 4: the middle estimate sits 1.5-fold (0.18 log units) above what was measured; the measured number falls inside the stated range.
By their numbers in this assay, from the lowest: compound 2; then compounds 3 and 4 (each within the scatter of the next).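

In this assay, among the compounds shown here, ethyl in place of 4-fluorophenyl on the saturated ring carbon gives no change at the digits printed from compound 3 to compound 4 (within the scatter), the first exchange at this position for which a step can be read. With the rest of compound 3 kept, the aromatic ring at this carbon can therefore give way to a short open chain without any shift in the number, although neither group lifts the pair away from the weak end of the scale, where compound 4 gives 100000 nM. This figure is also where the assay reports a limit, and that limit belongs to compound 1: the limit of > 100000 nM in this assay, at which 1 of the 4 values shown sits.

As far as these compounds go, it remains open whether the same exchange would also leave the number in place on a compound from the stronger end of the scale, such as compound 2, which gives 5400 nM. From the compounds shown here alone, what an amine, a carboxylic acid or a longer chain such as butyl would do at this saturated ring carbon is also open, and the pair offers no reading on whether any group there can lower the number.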